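This account rests on a few compounds, and the source may have more. Where it says the series, first, only, none or still open, it means among the compounds named here.

In a functional assay on SK-BR-3 cells (Homo sapiens) for cytotoxicity, read by trypan blue exclusion, with a stated time of 96 h (on this read-out higher numbers stand for weaker inhibition of growth and lower numbers for stronger inhibition of growth), compound 1 (`COc1ccc(NS(=O)(=O)/C=C/c2c(OC)cc(OC)cc2OC)cc1`) gives 50 nM and compound 2 (`COc1cc(OC)c(/C=C/S(=O)(=O)Nc2ccc(OC)c(O)c2)c(OC)c1`) gives 25 nM (within the scatter of each other). Compound 3 (`COc1cc(OC)c(/C=C/S(=O)(=O)Nc2ccc(OC)c(N)c2)c(OC)c1`) has amino in place of hydroxy on an aromatic carbon, ortho to a methoxy group (amino in place of hydroxy on an aromatic carbon). For the measured compounds named here, the one measured step (a 2.0-fold lower number from compound 1 to compound 2 (0.30 log units; within the scatter)) puts hydroxy in place of hydrogen at that carbon and stays within the scatter. Going by the values given here, no measured step covers amino. No step beyond the scatter is therefore expected in this assay. The expected step is small (a 1.2-fold higher number from compound 2 to compound 3 (0.08 log units; within the scatter)). Compound 3 is estimated at 30 nM (expected range 10 nM to 90 nM).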

Compound 3, concentration for 50% growth inhibition: 4 nM
The estimate for compound 3 lay 7.5-fold (0.88 log units) above the measured number, and the stated range ends above it.
By their numbers in this assay, from the lowest: compound 3; then compounds 2 and 1 (each within the scatter of the next).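

On the aromatic carbon ortho to a methoxy group, the exchange of hydroxy for amino gives a 6.3-fold lower number from compound 2 to compound 3 (0.80 log units; beyond the scatter) in this assay, so this position distinguishes between the two groups, although their counted hydrogen-bond donors and acceptors match. Amino in place of hydrogen gives a 13-fold lower number from compound 1 to compound 3 (1.10 log units; beyond the scatter), whereas hydroxy in place of hydrogen at this carbon stayed within the scatter. Nothing available explains why amino differs from hydroxy here.

Open, on these data alone, is whether a methylamino, dimethylamino or acetamido group at this carbon keeps the lower number. Also open, as far as these compounds go, is whether the amino result holds in other cell lines.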